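A few compounds are considered here, and "the series" means these few. Any claim that something is new, unique, unknown or untested is made for them only; others in the source may bear on it.

Measured so far in a functional assay on ASPC1 cells (Homo sapiens) for inhibition, read by MTT assay, with a stated time of 96 h; a lower number here means a stronger inhibitor of growth, a higher number a weaker inhibitor of growth:
- Compound 1 `C=CCOC(=O)SCCCCCCNC(=O)c1cc(-c2ccncc2)n[nH]1`: 27500 nM
- Compound 2 `CCCC(=O)SCCCCCCNC(=O)c1cc(-c2ccncc2)n[nH]1`: 28100 nM

With only these two values, compound 2 cannot be separated from compound 1, as they lie within the scatter of each other. Compound 3 `CCC(=O)SCCCCCCNC(=O)c1cc(-c2ccncc2)n[nH]1` differs from compound 2 in one place: hydrogen in place of methyl on a saturated chain carbon, two bonds along the chain from a carbonyl carbon. This is hydrogen in place of methyl on a saturated chain carbon, two bonds along the chain from a carbonyl carbon, so propyl becomes ethyl. Among the measured compounds shown here, only one measured step bears on this, and only loosely, since it concerns a different swap on the same carbonyl carbon, propyl in place of allyloxy: a 1.0-fold higher number from compound 1 to compound 2 (0.01 log units; within the scatter). That single step stays within the scatter, and it shows no pattern by itself. No step beyond the scatter is therefore expected in this assay. The expected step is a 1.0-fold lower number from compound 2 to compound 3 (0.00 log units; within the scatter). Compound 3 is estimated at 28000 nM, with an expected range of 15000 nM to 50000 nM.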

Compound 3, concentration for 50% growth inhibition: > 50000 nM
Compound 3 was reported as a limit; the forecaster's own chance of this, stated with the estimate: 5%; middle value at least 1.7-fold (0.25 log units) from the limit.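

In this assay compound 3 is reported only as a limit, > 50000 nM. Shortening propyl to ethyl on the carbonyl carbon gives an at least 1.7-fold higher number from compound 2 to compound 3 (0.25 log units; that floor lies within the scatter), and ethyl in place of allyloxy gives an at least 1.8-fold higher number from compound 1 to compound 3 (0.25 log units; that floor lies within the scatter). From the compounds shown here alone, the earlier swap at this carbonyl carbon stayed within the scatter, whereas these two steps have only a floor, so the removal of one methyl may matter here, but the floors do not show it, and their true size stays open because the reading ends at a limit: the limit of > 50000 nM in this assay, at which 1 of the 3 values shown sits.

Going by these compounds, whether a longer chain such as butyl on the same carbonyl carbon would lower or raise the number remains open. So does the effect of an amine or a carboxylic acid in place of propyl.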